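Ethyl for methyl on the aryl sulfonate side

The source may hold more compounds than are shown below. What is called first, only, known or untested is meant among the compounds shown, and "the series" means these compounds.

Working notes on the sulfonate-linked urea series. Compound 1 is `Cc1ccccc1OS(=O)(=O)c1ccc(NC(=O)NCCCCl)cc1`, compound 2 is `CCc1ccccc1OS(=O)(=O)c1ccc(NC(=O)NCCCCl)cc1` and compound 3 is `CCNC(=O)Nc1ccc(S(=O)(=O)Oc2ccccc2C)cc1`. In a functional assay on M21 cells (Homo sapiens) for cytotoxicity, read by sulforhodamine B assay, with a stated time of 48 h (a lower number here means a stronger inhibitor, a higher number a weaker inhibitor), compound 1 gives 25000 nM, compound 2 gives 15000 nM and compound 3 gives 3100 nM. For the measured compounds named here, compound 3 thus holds the lowest number of the three measured so far, and its separation from both compound 2 and compound 1 lies beyond the scatter; the step of an 8.1-fold lower number from compound 1 to compound 3 (0.91 log units; beyond the scatter) records the larger of those two gaps, the removal of the chloromethyl from the chain on the urea nitrogen.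

Compound 4, `CCNC(=O)Nc1ccc(S(=O)(=O)Oc2ccccc2CC)cc1`, has not yet been measured. It differs from compound 3 by methyl in place of hydrogen on a saturated chain carbon bound to an aromatic carbon. A single measured step bears directly on this change: a 1.7-fold lower number from compound 1 to compound 2 (0.22 log units; within the scatter), which carried out the same substitution within the chloropropyl urea pair and stayed inside the scatter. On that basis, for compound 4 the expected step is a 1.4-fold lower number from compound 3 to compound 4 (0.15 log units; within the scatter), at most a small drift toward a lower number and not clearly beyond the scatter. Compound 4 is estimated at 2200 nM, with an expected range of 1000 nM to 5000 nM.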

Compound 4, half-maximal inhibitory concentration: 2500 nM
Beside the measured number, compound 4's estimate is 1.1-fold (0.06 log units) below it; the measured number falls inside the stated range.
By their numbers in this assay, from the lowest: compounds 4 and 3 (each within the scatter of the next); then compounds 2 and 1 (each within the scatter of the next).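

In this assay, the step from 2-methylphenyl to 2-ethylphenyl, a 1.2-fold lower number from compound 3 to compound 4 (0.09 log units; within the scatter), now shows that this change stays within the scatter on the ethyl urea as well as on the chloropropyl urea, and the two readings agree: the same change on two cores in this assay, a 1.7-fold lower number (0.22 log units; within the scatter) from compound 1 to compound 2 and a 1.2-fold lower number (0.09 log units; within the scatter) from compound 3 to compound 4, 1.3-fold (0.13 log units) apart, within the scatter of two such steps The removal of chloromethyl, previously read only on the 2-methylphenyl compounds, also holds up with 2-ethylphenyl in place, giving a 6.0-fold lower number from compound 2 to compound 4 (0.78 log units; beyond the scatter), and the two steps are of matching size: the same change on two cores in this assay, an 8.1-fold lower number (0.91 log units; beyond the scatter) from compound 1 to compound 3 and a 6.0-fold lower number (0.78 log units; beyond the scatter) from compound 2 to compound 4, 1.3-fold (0.13 log units) apart, within the scatter of two such steps Across these four compounds, the chain on the urea nitrogen therefore accounts for the steps beyond the scatter, whereas methyl and ethyl on the aryl sulfonate side cannot be told apart.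

The compounds shown leave open whether isopropyl or tert-butyl in this place would still sit within the scatter of compound 3 and compound 4, since the series shown stops at ethyl here. They also cannot separate the loss of the chlorine from the shortening of the chain, a question that a plain propyl group on the urea nitrogen would address.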